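The source may report more compounds than this note shows. Statements on the series, on what has been measured and on what is new or still open speak of the compounds shown alone.

Measured so far:
- compound 1, `Cc1cccc(NC(=O)N[C@H](C)c2ccccc2)c1`: 98%
- compound 2, `CC(=O)c1cccc(NC(=O)N[C@H](C)c2ccccc2)c1`: 88%

In an ADME assay on the whole organism with Oryza sativa as the target, tested at 1 uM (on this read-out lower numbers stand for a stronger effect and higher numbers for a weaker effect at the one concentration tested), compound 2 stands at the lowest of the two numbers; its nearest neighbour is compound 1, and the step of a number 10 percentage points lower from compound 1 to compound 2 (within the scatter) lies within the scatter, so the two compounds cannot be separated on this read-out.

Compound 3, `C[C@@H](NC(=O)Nc1cccc(I)c1)c1ccccc1`, has not yet been measured. It differs from compound 2 as follows: iodo in place of acetyl on an aromatic carbon. Within the data shown here, the only measured step, a number 10 percentage points lower from compound 1 to compound 2 (within the scatter), exchanged one group on the same aromatic carbon without a change beyond the scatter. Among the measured compounds shown here, no measured step concerns the iodo group itself, so the expectation rests on that one step alone.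

Compound 3 is therefore expected to stay close to compound 2, with a step of a number 2 percentage points higher from compound 2 to compound 3 (within the scatter) that is not beyond the scatter. The estimate for compound 3 is 90%, within a range from 72% to 100%.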

Compound 3, a percentage reported as activity, at one concentration (the size of the read-out at that concentration, not a potency): 75%
Compound 3: middle estimate off by 15 percentage points, on the high side; measured number inside the range.
By their numbers in this assay, from the lowest: compound 3; then compounds 2 and 1 (each within the scatter of the next).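

In this assay the aromatic carbon meta to a large group now gives steps beyond the scatter, with iodo in place of acetyl as a number 13 percentage points lower from compound 2 to compound 3 (beyond the scatter) and with iodo in place of methyl as a number 23 percentage points lower from compound 1 to compound 3 (beyond the scatter) on the same core. Methyl and acetyl stayed within the scatter of each other, so this is the first sign that the group on this carbon can move the number, though both new steps are modest. No measurement at hand accounts for the difference between iodo and the other two groups.

From the compounds shown here alone, whether the lower number belongs to iodo alone or also appears with chloro or bromo on this carbon remains open. Also open, going by these compounds, are how an amine or a carboxylic acid would read here, and whether iodo on another carbon of the ring gives the same step.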